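The compounds below may be only part of what the source reports. "The series", "measured", "known", "first", "only" and "open" are said of these compounds alone.

Values measured so far in a physicochemical assay for solubility, in phosphate buffer; a lower number here means a less soluble compound, a higher number a more soluble compound
compound 1 `CC(=O)c1ccc(Nc2ccnc(-c3ccncc3)n2)cc1` gives 37000 nM
compound 2 `CCOC(=O)c1ccc(Nc2ccnc(-c3cccnc3)n2)cc1` gives 61000 nM

Compound 2 sits at 61000 nM in this pair, within the scatter of compound 1 at 37000 nM and so not distinguishable from it. Compound 3 `CC(=O)c1ccc(Nc2ccnc(-c3cccnc3)n2)cc1` keeps the rest of compound 2 but has methyl in place of ethoxy on a carbonyl carbon, so that ethoxycarbonyl becomes acetyl: methyl in place of ethoxy on a carbonyl carbon is the whole change. Within the data shown here, no two measured compounds differ in one place only, so the data hold no direct measure of this swap. Compound 1 also carries acetyl and gives 37000 nM in this assay as its reading, so no step beyond the scatter is expected. The estimate amounts to a 1.4-fold lower number from compound 2 to compound 3 (0.13 log units; within the scatter) and remains only an expectation. Compound 3 is estimated at 45000 nM with an expected range of 17000 nM to 120000 nM for a single measurement.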

Compound 3, solubility: 98000 nM
Compound 3: middle estimate off by 2.2-fold (0.34 log units), on the low side; the range from low to high includes it.
By their numbers in this assay, from the lowest: compounds 1, 2 and 3 (each within the scatter of the next, the first and the last beyond it).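

In this assay, among these compounds, the swap from ethoxycarbonyl to acetyl can now be read directly, with methyl in place of ethoxy on a carbonyl carbon giving a 1.6-fold higher number from compound 2 to compound 3 (0.21 log units; within the scatter) and so showing no step that can be told apart from repeat measurement. With acetyl held constant, pyridin-3-yl in place of pyridin-4-yl on an aromatic carbon gives a 2.6-fold higher number from compound 1 to compound 3 (0.42 log units; beyond the scatter) as a modest step, and of the two changes only this one lies beyond the scatter. No measurement on hand explains either step.

From the compounds shown here alone, each change has been read only once, so it remains open whether the swap on the carbonyl carbon would read the same with pyridin-4-yl in the compound. Also open, going by these compounds, is how other groups on that carbonyl carbon, such as an amine, a hydroxyl giving a carboxylic acid, or a longer chain, would read in this assay and whether any would step beyond the scatter.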